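Series notes: nitro in place of bromo on compound 2

The source may hold more compounds than are shown below. What is called first, only, known or untested is meant among the compounds shown, and "the series" means these compounds.

Measured so far:
compound 1, `COc1ccc(-c2nc3sc(Cc4ccccc4)nn3c2SC#N)cc1`, 72400 nM
compound 2, `O=Cc1c(-c2ccc(Br)cc2)nc2sc(Cc3ccccc3)nn12`, 13500 nM

In a functional assay on cells (Leukemia cell, Homo sapiens) for inhibition (on this read-out higher numbers stand for weaker inhibition of growth and lower numbers for stronger inhibition of growth), compound 1 gives 72400 nM, and compound 2 gives 13500 nM. Among the two numbers at hand, compound 2 stands lowest, and the gap up to compound 1 lies beyond the usual scatter, so compound 2 is the stronger inhibitor of growth of the pair. Among the measured compounds shown here, the two compounds differ in more than one place, so no single structural step connects them and nothing can be read from their pair about any one change.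

Compound 3, `O=Cc1c(-c2ccc([N+](=O)[O-])cc2)nc2sc(Cc3ccccc3)nn12`, is not yet measured in this assay. It differs from compound 2 as follows: nitro in place of bromo on an aromatic carbon. For the measured compounds named here, no measured pair shows a change of this kind, so there is no step to lean on. The expectation is a small step, if any, with no move beyond the scatter and no clear direction. Compound 3 is estimated at 11000 nM, with a range from 3500 nM to 35000 nM. On this expectation the step of a 1.2-fold lower number from compound 2 to compound 3 (0.09 log units; within the scatter) stays within the usual scatter.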

Compound 3, concentration for total growth inhibition: 26300 nM
Compound 3: middle estimate off by 2.4-fold (0.38 log units), on the low side, within the range that was stated.
By their numbers in this assay, from the lowest: compounds 2 and 3 (each within the scatter of the next); then compound 1.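

In this assay, nitro in place of bromo on the aromatic carbon para to a large group gives a 1.9-fold higher number from compound 2 to compound 3 (0.29 log units; within the scatter), so this pair cannot be told apart on growth inhibition. Among the compounds shown here, this is the first single-place comparison, and it shows that at this position the read-out stays within the scatter when bromo gives way to nitro, a group that brings hydrogen-bond acceptors and a double bond outside aromatic rings, neither of which bromo has. No measurement of any property of these two groups bears on this step, and the pair offers no explanation for it.

On these data alone, with only bromo and nitro compared at this position, it remains open whether an amine, a carboxylic acid or a longer chain in the same place would also stay within the scatter. For the compounds shown here, compound 1 differs from the other two compounds in more than one place, so the separate contributions of its methoxy and thiocyanate groups also remain open, and no single-place pair yet speaks to either group.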